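The source may hold more compounds than are shown below. What is called first, only, known or untested is meant among the compounds shown, and "the series" means these compounds.

Among the compounds with values here, the set of three measured compounds shares a common core, and compound 1 `COc1cc(NC(=O)Nc2cc(Nc3ccc(OC)c(C)c3)ncn2)cc(OC)c1` is the one from which the step is taken. In a functional assay on HCC827 cells (Homo sapiens) for inhibition, read by MTT assay, with a stated time of 48 h, tested at 10 uM (a higher number here means more inhibition at the concentration tested (going by the name of the read-out), a lower number less inhibition), compound 1 gives 48.3%, the second highest of the three numbers. Compound 2 `COc1cc(Br)ccc1Nc1cc(NC(=O)Nc2c(Cl)cccc2Cl)ncn1` gives 42.7% in this assay, a value within the scatter of compound 1, so the two are not told apart. Compound 3 `COc1ccc(C(F)(F)F)cc1Nc1cc(NC(=O)Nc2c(Cl)cccc2Cl)ncn1` gives 68.7% in this assay, a value beyond the scatter above compound 1, though no single step connects the two compounds, and only their two values are shown.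

Compound 4 `COc1cc(NC(=O)Nc2cc(Nc3cccc(C(C)(C)C)c3)ncn2)cc(OC)c1` is not yet measured. It differs from compound 1 by one change: 3-(tert-butyl)phenyl in place of 4-methoxy-3-methylphenyl on a nitrogen on an aromatic ring. Within the data shown here, no measured pair shows this exchange, so no size of step can be drawn from the data. Compound 4 is expected to stay close to compound 1, with a step of a number 3.3 percentage points lower from compound 1 to compound 4 (within the scatter) not beyond the scatter in either direction. In this assay compound 4 is therefore estimated at 45%, within a range from 25% to 65%.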

Compound 4, a percentage reported as inhibition, at one concentration (the size of the read-out at that concentration, not a potency): 48.7%
Beside the measured number, compound 4's estimate is 3.7 percentage points below it; the measured number falls inside the stated range.
By their numbers in this assay, from the lowest: compounds 2, 1 and 4 (each within the scatter of the next); then compound 3.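

Among the earlier compounds, no pair differed in one place, so this is the first reading of a change at this position, on a nitrogen on an aromatic ring. In this assay, 3-(tert-butyl)phenyl in place of 4-methoxy-3-methylphenyl gives a number 0.4 percentage points higher from compound 1 to compound 4 (within the scatter), so the two compounds are not told apart, even though a group of carbon only replaces one that carries an oxygen. Nothing available explains why the reading holds across this exchange.

The compounds shown leave open whether this holds for every group at this position, since only two aromatic groups are compared on this core. An amine or a carboxylic acid on this phenyl ring, or a longer alkyl chain in place of the ring, could give a different reading.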